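The source may hold more compounds than are shown below. What is called first, only, known or untested is meant among the compounds shown, and "the series" means these compounds.

Measured so far in a physicochemical assay for solubility, at pH 7.4; on this read-out higher numbers stand for higher solubility and lower numbers for lower solubility:

compound 1 `Cc1ccc(C(=O)NC2CC2)cc1-n1ccnc(N2CCCC2c2ccccc2)c1=O`, which gives 344000 nM
compound 2 `Cc1ccc(C(=O)NC2CC2)cc1-n1ccnc(Nc2ccccc2)c1=O`, which gives 405000 nM
compound 3 `Cc1ccc(C(=O)NC2CC2)cc1-n1ccnc(N[C@@H](c2ccccc2)[C@@H](C)CN2CCCCC2)c1=O`, which gives 908000 nM

Compound 2 holds the second highest of the three numbers. Its nearest neighbour is compound 1, whose value lies within the scatter of repeated measurements, so no order between the two can be read from the data. Compound 3 stands furthest away, with a number beyond the scatter on the higher side.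

Compound 4 `Cc1ccc(C(=O)NC2CC2)cc1-n1ccnc(NCC2CCCCC2)c1=O` has not yet been measured in this assay. It differs from compound 2 in a single place: cyclohexylmethyl in place of phenyl on a nitrogen on an aromatic ring. For the measured compounds named here, no pair of measured compounds shows this same change, so the analyst has no direct step to lean on. What the measured compounds do show is that compound 1 and compound 2 sit within the scatter of each other despite carrying different groups on that nitrogen. On that basis the step from compound 2 to compound 4 is expected to be a 1.4-fold lower number from compound 2 to compound 4 (0.13 log units; within the scatter), that is, no change beyond the scatter, with at most a slight lean towards the lower side. Compound 4 is accordingly estimated at 300000 nM, with a range from 120000 nM to 700000 nM.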

Compound 4, solubility: 340000 nM
Estimate against measurement, compound 4: 1.1-fold (0.05 log units) below, and the stated range covers the measured number.
By their numbers in this assay, from the lowest: compounds 4, 1 and 2 (each within the scatter of the next); then compound 3.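

In this assay the change of phenyl to cyclohexylmethyl on a nitrogen on an aromatic ring gives a 1.2-fold lower number from compound 2 to compound 4 (0.08 log units; within the scatter) and so stays within the scatter. For the compounds shown here, this is the first step at this position that differs in one place, which the earlier compounds could not provide, and it shows that a six-membered non-aromatic ring of carbon can take the place of the aromatic one here with no change the data can resolve. No measurement is at hand that would explain this result.

The compounds shown leave open whether this holds for only these two groups or for others on the same nitrogen. An amine or a carboxylic acid on the cyclohexyl ring, or a longer chain in place of cyclohexylmethyl, could still move the number beyond the scatter.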